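Fluoro for Chloro on the Benzylsulfanyl Arm

A few compounds are considered here, and "the series" means these few. Any claim that something is new, unique, unknown or untested is made for them only; others in the source may bear on it.

The measured compounds and their values:
compound 1, `CC1=C(C(=O)Nc2ccc(F)cc2)C(c2ccc([N+](=O)[O-])cc2)N=C(SCc2ccc(Cl)cc2)N1`, 28.2%;
compound 2, `CC1=C(C(=O)Nc2ccc(F)cc2)C(c2ccc([N+](=O)[O-])cc2)N=C(SCc2ccc(F)cc2)N1`, 25.6%;
compound 3, `COc1ccc(C2N=C(SCc3ccc(Cl)cc3)NC(C)=C2C(=O)Nc2ccc(Br)cc2)cc1`, 30.3%.

All three were tested in a functional assay on the whole organism (artery, strain albino) with Rattus norvegicus as the target, with a stated time of 600 min, at a dose of 10 mg/kg by the oral route; a lower number here means less inhibition, a higher number more inhibition at the dose given (going by the name of the read-out). Compound 1 and compound 2 share their core and differ only by fluoro in place of chloro on an aromatic carbon. The step this makes is a number 2.6 percentage points lower from compound 1 to compound 2 (within the scatter), so the two compounds cannot be told apart by this read-out. Compound 3 carries a different core; the difference between the two cores is not broken down here. In this assay compound 3 gives 30.3%, and its values against compound 1 and compound 2 both lie within the scatter, so no order among the three can be claimed.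

Compound 4, `COc1ccc(C2N=C(SCc3ccc(F)cc3)NC(C)=C2C(=O)Nc2ccc(Br)cc2)cc1`, has not yet been measured. It stands to compound 3 as compound 2 stands to compound 1: the change is fluoro in place of chloro on an aromatic carbon, at a place described in the same words for both pairs, so it is the same change made on a second core. Among the measured compounds shown here, because the only measured instance of this change, a number 2.6 percentage points lower from compound 1 to compound 2 (within the scatter), stayed within the scatter, the step from compound 3 is expected to be equally small, at a number 2.3 percentage points lower from compound 3 to compound 4 (within the scatter). Compound 4 is therefore estimated to give about 28% in this assay, with a likely range from 18% to 38%, resting on a single precedent and on the scatter of such whole-organism measurements.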

Compound 4, a percentage reported as inhibition, in the whole organism at one dose (the size of the read-out at that dose, not a potency): 24.1%
The estimate for compound 4 lay 3.9 percentage points above the measured number, within the range that was stated.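

On the second core, fluoro in place of chloro gives a number 6.2 percentage points lower from compound 3 to compound 4 (within the scatter) in this assay, so this pair cannot be told apart by this read-out, just as the pair on the first core could not. Set side by side, the two steps do not differ from each other, and so the change carries from one core to the other without any detectable difference in this read-out: the same change on two cores in this assay, a number 2.6 percentage points lower (within the scatter) from compound 1 to compound 2 and a number 6.2 percentage points lower (within the scatter) from compound 3 to compound 4, 3.6 percentage points apart, within the scatter of two such steps This does not show that the change is without effect or that the two cores respond to it identically, since a smaller real effect or a modest difference between the cores could lie hidden in the scatter of this single-dose, whole-organism read-out, and two pairs say nothing about other cores in the series.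

The compounds shown hold only chloro and fluoro at this place on the benzyl arm, para to a large group, so it remains open what a nitrile, an amine or a carboxylic acid there would give in this assay. As far as these compounds go, it also remains open whether any of the other groups on these cores, taken one at a time, would move this read-out beyond the scatter.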